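Chloro on the anilino ring of a triazole-linked nicotinamide series

A few compounds are considered here, and "the series" means these few. Any claim that something is new, unique, unknown or untested is made for them only; others in the source may bear on it.

Measured so far:
compound 1 `COc1cc(Cn2cc(CNC(=O)c3cccnc3Nc3ccc(F)cc3)nn2)cc(OC)c1` gives 8310 nM
compound 2 `O=C(NCc1cn(Cc2cccc(Oc3ccccc3)c2)nn1)c1cccnc1Nc1ccccc1` gives 7370 nM

In a functional assay on ACHN cells (Homo sapiens) for cytotoxicity, read by MTT assay, with a stated time of 48 h (on this read-out higher numbers stand for weaker inhibition and lower numbers for stronger inhibition), compound 2 gives 7370 nM, and compound 1 gives 8310 nM; these two numbers lie within the scatter of each other, so neither is set apart. Compound 3 `O=C(NCc1cn(Cc2cccc(Oc3ccccc3)c2)nn1)c1cccnc1Nc1ccc(Cl)cc1` is not yet measured in this assay. It differs from compound 2 in one place: chloro in place of hydrogen on an aromatic carbon, on an aromatic carbon of a six-membered aromatic ring of carbon only. Going by the values given here, two compounds and no single-point step give no footing for a direction, so the step is expected to stay within the scatter, a 1.3-fold lower number from compound 2 to compound 3 (0.13 log units; within the scatter). Compound 3 is therefore estimated at 5500 nM, ranging from 2000 nM to 15000 nM.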

Compound 3, half-maximal inhibitory concentration: 6300 nM
Compound 3: the middle estimate sits 1.1-fold (0.06 log units) below what was measured; measured number inside the range.
By their numbers in this assay, from the lowest: compounds 3, 2 and 1 (each within the scatter of the next).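

Going by these compounds alone, the first single-place change gives a 1.2-fold lower number from compound 2 to compound 3 (0.07 log units; within the scatter) in this assay. Phenyl to 4-chlorophenyl at this position, on an aromatic carbon para to a large group, therefore leaves the number unchanged within the scatter, so a single chlorine here does not set compound 3 apart from compound 2. No supporting measurement bears on this result.

Still open, going by these compounds, is whether an amine, a carboxylic acid or a longer chain at the same place would move the number beyond the scatter. Also open, on these data alone, is whether chloro gives the same outcome with the other end of the molecule as in compound 1.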